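A few compounds are considered here, and "the series" means these few. Any claim that something is new, unique, unknown or untested is made for them only; others in the source may bear on it.

Working notes on the series.

Compound 1 `COc1nc(N)nc2c1c(-c1cc3ccccc3o1)cn2[C@@H]1O[C@H](CO)[C@@H](O)[C@H]1O` is the reference. In an ADME assay on BJ cells (Homo sapiens), read by MTT assay, with a stated time of 72 h (a lower number here means a stronger inhibitor, a higher number a weaker inhibitor), compound 1 gives 25600 nM, which is the only numerical result in the set. Compound 2 `Nc1nc(N)c2c(-c3cc4ccccc4o3)cn([C@@H]3O[C@H](CO)[C@@H](O)[C@H]3O)c2n1` reaches only the limit > 100000 nM in this assay. Compound 3 `CNc1ncnc2c1c(-c1ccccc1)cn2[C@@H]1O[C@H](CO)[C@@H](O)[C@H]1O` likewise reaches only the limit > 100000 nM in this assay. Going by the values given here, the one directly comparable step, an at least 3.9-fold higher number from compound 1 to compound 2 (0.59 log units; beyond the scatter), already points toward weaker inhibition when the methoxy group is altered, and the limit of > 100000 nM in this assay, at which 2 of the 3 values shown sit, shows that most of the series sits at the assay ceiling.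

Compound 4 `COc1ncnc2c1c(-c1cc3ccccc3o1)cn2[C@@H]1O[C@H](CO)[C@@H](O)[C@H]1O` differs from compound 1 by hydrogen in place of amino on an aromatic carbon. Among the compounds with values here, no measured pair isolates this change, so the expectation rests on the general standing of compound 1 as the sole compound below the ceiling and on the step from compound 1 to compound 2, which moved a substituent change on the same ring beyond the scatter toward weaker inhibition. A move of similar character, a 2.3-fold higher number from compound 1 to compound 4 (0.37 log units; beyond the scatter), is expected here, with a real chance that only a limit is returned. Compound 4 is therefore estimated at 60000 nM in this assay, within a range from 15000 nM to 250000 nM.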

Compound 4, half-maximal inhibitory concentration: 22400 nM
The estimate for compound 4 lay 2.7-fold (0.43 log units) above the measured number; the range from low to high includes it.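

In this assay the change appears as a 1.1-fold lower number from compound 1 to compound 4 (0.06 log units; within the scatter), so compound 1 and compound 4 cannot be told apart, and this assay does not register the exchange of amino for hydrogen on the aromatic carbon between two ring nitrogen atoms. The earlier compounds shown here offered only a step at the methoxy group, an at least 3.9-fold higher number from compound 1 to compound 2 (0.59 log units; beyond the scatter), and so gave no reading at this position; the two steps now show a difference at one place on the ring and none at the other. A numerical result no longer rests on compound 1 alone, though the assay limit still bounds much of the set: the limit of > 100000 nM in this assay, at which 2 of the 4 values shown sit.

On these data alone, whether this position tolerates any group in this assay stays open, since only amino and hydrogen are compared there, and a dimethylamino group, a methyl group or a chlorine atom at the same carbon could read differently. As far as these compounds go, it is also open whether hydrogen in place of amino would read the same with another group in place of methoxy, such as an ethoxy group or a longer chain.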